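The compounds below may be only part of what the source reports. "The series", "measured", "known", "first", "only" and "open" are said of these compounds alone.

Three compounds share a core bearing a sulfamate on a fused bicyclic amine, and differ in the group attached through an amide. Compound 1 `CCN(Cc1ccc(Br)cc1)c1cccc(C(=O)N2CCc3ccc(OS(N)(=O)=O)cc3C2)c1` gives, in an assay on HEK293 cells for inhibition of Steryl-sulfatase (Homo sapiens), tested at 1 uM (a lower number here means a weaker effect, a higher number a stronger effect of the compound at the concentration tested), a value of 84.5%. Compound 2 `CCN(Cc1ccc(Br)cc1)c1ccc(C(=O)N2CCc3ccc(OS(N)(=O)=O)cc3C2)cc1` gives 95.9% in this assay; compound 1 and compound 2 have the same atoms joined differently, and the difference between their two cores is not broken down here. Compound 3 `CCN(Cc1ccncc1)c1ccc(C(=O)N2CCc3ccc(OS(N)(=O)=O)cc3C2)cc1` gives 86.6% in this assay. The change pyridin-4-yl in place of 4-bromophenyl on a saturated chain carbon bound to a nitrogen on an aromatic ring produced a number 9.3 percentage points lower from compound 2 to compound 3 (within the scatter). Compound 4 `CCN(Cc1ccncc1)c1cccc(C(=O)N2CCc3ccc(OS(N)(=O)=O)cc3C2)c1` has not yet been measured; it arises from compound 1 through (pyridin-4-yl in place of 4-bromophenyl on a saturated chain carbon bound to a nitrogen on an aromatic ring), the same change in the same place as that from compound 2 to compound 3. The step of a number 8.5 percentage points lower from compound 1 to compound 4 (within the scatter) is what is expected here, resting on the measured step of a number 9.3 percentage points lower from compound 2 to compound 3 (within the scatter). On that basis compound 4 is estimated to give 76% in this assay, between 60% and 90%.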

Compound 4, a percentage reported as inhibition, at one concentration (the size of the read-out at that concentration, not a potency): 52.8%
Beside the measured number, compound 4's estimate is 23.2 percentage points above it; the measured number lies below the stated range.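

In this assay, replacing 4-bromophenyl with pyridin-4-yl on the core of compound 1 gave a number 31.7 percentage points lower from compound 1 to compound 4 (beyond the scatter), so this change cost far more here than the earlier pair suggested. The size of the step therefore did not carry over from one core to the other: the same change on two cores in this assay, a number 9.3 percentage points lower (within the scatter) from compound 2 to compound 3 and a number 31.7 percentage points lower (beyond the scatter) from compound 1 to compound 4, 22.4 percentage points apart, beyond the scatter of two such steps. For the compounds shown here, this shows that, in this small set, a step measured on one core is an unsafe guide to the same change on the other; it rests on only two pairs, read at a single concentration, and it does not show why the two cores part ways or whether other changes would behave the same way.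

The compounds shown leave open whether the gap between the cores belongs to pyridin-4-yl itself or would also appear with another group in the same place, such as pyridin-3-yl or plain phenyl. They also leave open what a shorter methyl in place of the ethyl on the nitrogen would do on either core.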